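Chalcone-pyrazole series: halogen swap on the aryl ketone

A few compounds are considered here, and "the series" means these few. Any claim that something is new, unique, unknown or untested is made for them only; others in the source may bear on it.

Measured so far:
compound 1, `COc1cc(-c2cc(/C=C/C(=O)c3ccc(Cl)c(Cl)c3)[nH]n2)cc(OC)c1OC` — 62%
compound 2, `COc1cc(C(=O)/C=C/c2cc(-c3cc(OC)c(OC)c(OC)c3)n[nH]2)cc(OC)c1OC` — 40%

In a functional assay on MCF7 cells (Homo sapiens) for cytotoxicity, read by sulforhodamine B assay, with a stated time of 48 h, tested at 1 uM (a higher number here means a weaker effect of the compound at the concentration tested, a lower number a stronger effect), compound 1 gives 62%, the highest of the two numbers recorded. Its nearest neighbour is compound 2, which in this assay gives 40%; the gap between the two lies beyond the scatter. The two compounds share no single-point relationship, so only their two values can be compared.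

Compound 3, `COc1cc(-c2cc(/C=C/C(=O)c3ccc(F)c(F)c3)[nH]n2)cc(OC)c1OC`, has not yet been measured. Relative to compound 1 the change is 3,4-difluorophenyl in place of 3,4-dichlorophenyl on a carbonyl carbon. For the measured compounds named here, no step of this kind has been measured, so its size is unknown here. The expectation is that the step from compound 1 to compound 3 in this assay is a number 3 percentage points higher from compound 1 to compound 3 (within the scatter), that is, no change beyond the scatter. Compound 3 is accordingly estimated at 65%, within the range 45% to 85%.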

Compound 3, a percentage reported as activity, at one concentration (the size of the read-out at that concentration, not a potency): 99%
Beside the measured number, compound 3's estimate is 34 percentage points below it; the measured number lies above the stated range.
By their numbers in this assay, from the lowest: compound 2; then compound 1; then compound 3.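

In this assay, for the compounds shown here, 3,4-difluorophenyl in place of 3,4-dichlorophenyl on a carbonyl carbon gives a number 37 percentage points higher from compound 1 to compound 3 (beyond the scatter), the only single-place step so far. The read-out at this position is therefore sensitive to the identity of the halogen: with the rest of the structure unchanged, the effect is weaker with the two fluorines, and compound 3 gives 99%. Nothing available bears on what lies behind this step.

On these data alone, how a 3,4-dibromophenyl, a 4-chlorophenyl or an unsubstituted phenyl group on this carbonyl carbon would read remains open, so a single step cannot yet separate the effect of halogen identity from that of the substitution pattern. Also open, as far as these compounds go, is whether a ring carrying an amine such as morpholine would be tolerated at this position.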